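The source may report more compounds than this note shows. Statements on the series, on what has been measured and on what is new or still open speak of the compounds shown alone.

Compound 1, `COc1cc(OC)c(OC)cc1/C=C/COC(=O)/C=C/c1ccccc1C(F)(F)F`, was examined in a functional assay on the whole organism (strain Kunming) with Mus musculus as the target, with a stated time of 0.5 h, at a dose of 300 mg/kg by the intraperitoneal route; on this read-out higher numbers stand for a weaker effect at the one dose given and lower numbers for a stronger effect. In this assay compound 1 gives 100%. Its nearest neighbour among the measured compounds is compound 2, `COc1cc(OC)c(OC)cc1/C=C/COC(=O)/C=C/c1cc(OC)c(OC)c(OC)c1`, which in this assay gives 100%; the two readings agree at the digits recorded, so compound 1 stands level with compound 2 and the gap between them lies within the scatter of repeated measurements. For the measured compounds named here, no step between measured compounds differing in a single place is available, so the account rests on these two values alone.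

The compound still to be measured is compound 3, `COc1ccc(/C=C/C(=O)OC/C=C/c2cc(OC)c(OC)cc2OC)cc1`. It differs from compound 1 in one place: 4-methoxyphenyl in place of 2-(trifluoromethyl)phenyl on a double-bonded chain carbon bound to a double-bonded chain carbon. Because compound 2 gives 100% and compound 1 gives 100% with different groups at that place, the reading in this assay appears unmoved by exchanges there, at least across these two compounds. In this assay the expected step is no change at the digits printed from compound 1 to compound 3 (within the scatter), which is to say none beyond the scatter. Compound 3 is therefore estimated at 100%, within an expected range from 85% to 100%.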

Compound 3, a percentage reported as activity, at one dose (the size of the read-out at that dose, not a potency): 100%
Estimate against measurement, compound 3: no gap at the digits printed; measured number inside the range.
By their numbers in this assay, from the lowest: compounds 1, 2 and 3 (each within the scatter of the next).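

For the compounds shown here, this is the first single-place exchange at this position, on a double-bonded chain carbon bound to a double-bonded chain carbon, and in this assay replacing 2-(trifluoromethyl)phenyl with 4-methoxyphenyl gives no change at the digits printed from compound 1 to compound 3 (within the scatter) as its result. Compounds 1 and 2 could only suggest that this position made little difference, whereas this direct pair shows that the reading does not separate an aromatic group carrying fluorine and no hydrogen-bond acceptor from one carrying oxygen and one hydrogen-bond acceptor. Nothing available accounts for this lack of separation, so the result remains an observation without an explanation.

The compounds shown leave open whether any group at this position can move the reading, since every exchange here keeps a six-membered aromatic ring of carbon only, and an amine, a carboxylic acid or a longer chain in its place remains untested in this account. They also leave open whether an amide in place of the ester, or a change elsewhere on the shared core, would separate these compounds in this assay.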